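The compounds below may be only part of what the source reports. "The series", "measured", "known", "first", "only" and "open" are said of these compounds alone.

Measured compounds:
compound 1, `O=C(Nc1cc(Sc2ncn[nH]2)c(O)c2ccccc12)c1ccc([N+](=O)[O-])cc1`: > 100000 nM
compound 2, `O=C(Nc1cc(Sc2ncnc3nc[nH]c23)c(O)c2ccccc12)c1ccc(Cl)cc1`: 23000 nM
compound 3, `COc1ccc(/C=C/C(=O)Nc2cc(Sc3ncn[nH]3)c(O)c3ccccc23)cc1OC`: 52500 nM

All three were tested in a functional assay on MDA-MB-231 cells (Homo sapiens) for antiproliferative activity, read by MTT assay, with a stated time of 48 h; a higher number here means a weaker inhibitor, a lower number a stronger inhibitor. For the measured compounds named here, compound 1 gives > 100000 nM, which is a limit of the assay rather than a measured number, and it is the one value that sits at the limit of > 100000 nM in this assay, at which 1 of the 3 values shown sits. Going by the values given here, compound 2 gives 23000 nM and compound 3 gives 52500 nM; both are measured numbers, and since the two differ from compound 1 in more than one place, no single step between measured compounds can be read off here.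

Compound 4, `O=C(Nc1cc(Sc2ncn[nH]2)c(O)c2ccccc12)c1cccc(Cl)c1`, has not yet been measured in this assay. It differs from compound 1 by 3-chlorophenyl in place of 4-nitrophenyl on a carbonyl carbon. Because compound 1 gives only > 100000 nM, the direction of this change cannot be taken from a measured pair, and the expected step from compound 1 to compound 4 is an at least 1.6-fold lower number from compound 1 to compound 4 (0.22 log units; that floor lies within the scatter), toward a measurable number. Compound 4 is therefore estimated at 60000 nM in this assay, with a likely range from 20000 nM to 200000 nM.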

Compound 4, half-maximal inhibitory concentration: > 100000 nM
Compound 4: a limit, no number (the forecaster's own chance of this, stated with the estimate: 40%); middle value at least 1.6-fold (0.22 log units) away from the limit.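

In this assay compound 4 gives > 100000 nM, which is a limit of the assay and not a number. Compound 1 also stands at a limit, so no step can be read between compound 1 and compound 4: the limit of > 100000 nM in this assay, at which 2 of the 4 values shown sit.

The compounds shown leave open whether 3-chlorophenyl and 4-nitrophenyl on this carbonyl carbon differ at all in this assay.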